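From ethylamino to butylamino on a shared core

This account rests on a few compounds, and the source may have more. Where it says the series, first, only, none or still open, it means among the compounds named here.

In a functional assay on the whole organism for inhibition, with Mus musculus as the target (on this read-out lower numbers stand for an effect already at smaller amounts and higher numbers for an effect only at larger amounts of compound), compound 1 `CN1Cc2c(N)cccc2C(c2ccc(Cl)cc2)C1` gives 1.1 mg/kg, and compound 2 `CCOC(=O)Nc1cccc2c1CN(C)CC2c1ccc(Cl)cc1`, with ethoxycarbonyl on the nitrogen on an aromatic ring, gives 0.6 mg/kg, within the scatter of it. Compound 3 `CCNCC(=O)Nc1cccc2c1CN(C)CC2c1ccc(Cl)cc1`, carrying ((ethylamino)methyl)carbonyl there instead, has the highest number of the three at 6.4 mg/kg. The relevant steps are a 5.8-fold higher number from compound 1 to compound 3 (0.76 log units; beyond the scatter) and an 11-fold higher number from compound 2 to compound 3 (1.03 log units; beyond the scatter). Compound 4 `CCCCNCC(=O)Nc1cccc2c1CN(C)CC2c1ccc(Cl)cc1` turns ethylamino into butylamino, with ethyl in place of hydrogen on a saturated chain carbon, two bonds along the chain from an amine nitrogen. Within the data shown here, those steps show that this side group can shift the number, yet no measured step changes the chain length alone. The expected step is a 1.1-fold lower number from compound 3 to compound 4 (0.03 log units; within the scatter), so no shift beyond the scatter is expected. The estimate for compound 4 is 6 mg/kg, with an expected range of 2.5 mg/kg to 15 mg/kg.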

Compound 4, dose for half-maximal effect: 3.9 mg/kg
For compound 4 the middle estimate is 1.5-fold (0.19 log units) above the measured one, within the range that was stated.
By their numbers in this assay, from the lowest: compounds 2 and 1 (each within the scatter of the next); then compounds 4 and 3 (each within the scatter of the next).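

Going from ethylamino to butylamino gives the first step that changes only the chain, and in this assay this added ethyl does not separate the two compounds (a 1.6-fold lower number from compound 3 to compound 4 (0.22 log units; within the scatter)). Compound 4 also stays apart from the two compounds without this side group (a 6.5-fold higher number from compound 2 to compound 4 (0.81 log units; beyond the scatter) and a 3.5-fold higher number from compound 1 to compound 4 (0.55 log units; beyond the scatter)), so swapping ethyl for butyl does not remove the gap first seen with compound 3. Nothing available explains these numbers.

On these data alone, whether a longer chain such as hexyl would shift the number beyond the scatter remains open. So does the effect of a ring such as cyclohexyl or a hydroxyl group at the chain end.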